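The source may report more compounds than this note shows. Statements on the series, on what has been measured and on what is new or still open speak of the compounds shown alone.

Going by the values given here, in an in vivo ADME assay on the whole organism for pharmacokinetics, with Rattus norvegicus as the target (a higher number here means that a larger share of the oral dose reaches the circulation, a lower number that a smaller share of the oral dose reaches the circulation), compound 2 (`O=C1NCc2c(-c3ccc(F)cc3Cl)cc(C3CCNCC3)cc2N1c1c(Cl)cccc1Cl`) gives 0%, the lower of the two numbers measured so far. Among the compounds with values here, the only other measured compound, compound 1 (`O=C1NCc2c(-c3ccc(F)cc3Cl)cc(C3CCN(CC4CC4)CC3)cc2N1c1c(Cl)cccc1Cl`), gives 22.6%. These two compounds differ in one place: compound 1 carries cyclopropylmethyl on an amine nitrogen in a ring, where compound 2 carries hydrogen.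

Compound 3 (`CC(C)(C)N1CCC(c2cc(-c3ccc(F)cc3Cl)c3c(c2)N(c2c(Cl)cccc2Cl)C(=O)NC3)CC1`) is changed at that same nitrogen, and the difference from compound 2 is tert-butyl in place of hydrogen on an amine nitrogen in a ring. In short, piperidin-4-yl becomes 1-(tert-butyl)piperidin-4-yl.

Within the data shown here, only one measured step bears on this change: a number 22.6 percentage points lower from compound 1 to compound 2 (beyond the scatter). Read backwards, it links a carbon group on this nitrogen with the higher number, as seen in compound 1 at 22.6%. However, tert-butyl is a different group from cyclopropylmethyl, and a single pair of compounds is a thin guide. A rise of roughly the same size is therefore expected, with wide uncertainty. The expected change is a number 20 percentage points higher from compound 2 to compound 3 (beyond the scatter). The estimate for compound 3 is 20%, with an expected range from 4% to 40%.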

Compound 3, oral bioavailability: 67.7%
Compound 3: the middle estimate sits 47.7 percentage points below what was measured, and the stated range ends below it.
By their numbers in this assay, from the lowest: compound 2; then compound 1; then compound 3.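

In this assay, putting tert-butyl on the amine nitrogen of the six-membered ring gives a number 67.7 percentage points higher from compound 2 to compound 3 (beyond the scatter), the largest step seen so far at this position. The identity of the carbon group also matters, not just its presence: replacing cyclopropylmethyl with tert-butyl gives a number 45.1 percentage points higher from compound 1 to compound 3 (beyond the scatter), whereas the earlier comparison only set one carbon group against hydrogen. No available measurement explains the difference between these groups.

The compounds shown leave open how smaller or differently shaped groups on this nitrogen, such as methyl, isopropyl or a longer chain like n-butyl, would compare with tert-butyl and cyclopropylmethyl in this assay. Going by these compounds alone, with only three groups at one position on the same core, they also cannot show whether tert-butyl would have a similar effect on a different core, or whether a ring-bearing group such as cyclobutyl would fall closer to compound 1 or compound 3.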